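The source may report more compounds than this note shows. Statements on the series, on what has been measured and on what is new or still open speak of the compounds shown alone.

Within the data shown here, compound 1, `Brc1cccc2c1nnn2CC1CC1`, is the only member of this small set with a number in an ADME assay on microsomes from liver (Homo sapiens) for metabolic stability, tested at 2.5 uM; a lower number here means slower removal, a higher number faster removal of the compound; in this assay compound 1 gives 1.3 mL/min/g. Its two companions carry no result: compound 2, `CCn1nnc2c(Br)cccc21`, is reported as "not determined" (no result reported) in this assay, and compound 3, `Cn1nnc2c(Br)cccc21`, likewise as "not determined" (no result reported). Compound 1 therefore stands alone as the sole reference point, with nothing to rank it against.

The next compound, compound 4, `Clc1cc(Br)c2nnn(CC3CC3)c2c1`, differs from compound 1 in one place: chloro in place of hydrogen on an aromatic carbon. Among the measured compounds shown here, no pair of measured compounds traces this change, so its effect on clearance in this assay is unknown from the data. The expectation rests only on compound 1 and its value of 1.3 mL/min/g. The step from compound 1 to compound 4 is expected to be small, a 1.2-fold higher number from compound 1 to compound 4 (0.09 log units; within the scatter), not beyond the usual scatter in either direction. Compound 4 is thus estimated at 1.6 mL/min/g in this assay, with a range from 0.7 mL/min/g to 3.5 mL/min/g.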

Compound 4, intrinsic clearance in a liver preparation (reported as CLH), per the amount of preparation that the assay uses: 0.5 mL/min/g
For compound 4 the middle estimate is 3.2-fold (0.51 log units) above the measured one; measured number below the stated range.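

Among these compounds, the chloro group on this aromatic carbon, meta to a bromo group and para to a fused ring, gives the first readable change in this assay with a 2.6-fold lower number from compound 1 to compound 4 (0.41 log units; beyond the scatter) as its step, which lies beyond the scatter. Among the compounds shown here, until now the set held a single number, so this pair is the first sign that this position of the shared core can shift the read-out, and here it shifts towards slower removal. Nothing among the data shown accounts for the change.

Going by these compounds, whether this shift belongs to chloro in particular remains open, since a single group at one position cannot show how a fluoro atom, a methoxy group, a nitrile or an amine would behave there. On these data alone, the other free aromatic carbons of the core also remain open.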